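Lengthening the isothiocyanate tether on an amide-linked analogue

This account rests on a few compounds, and the source may have more. Where it says the series, first, only, none or still open, it means among the compounds named here.

Compound 1, `CN(C)C(=O)c1cc2cnc(Nc3ccc(S(=O)(=O)NCCCCCCCN=C=S)cc3)nc2n1C1CCCC1`, gives 32.6% in a functional assay on A549 cells (Homo sapiens) for inhibition, read by CCK-8 assay, with a stated time of 72 h, tested at 1 uM; on this read-out lower numbers stand for a weaker effect and higher numbers for a stronger effect at the one concentration tested.
Compound 2, `CN(C)C(=O)c1cc2cnc(Nc3ccc(C(=O)NCCCN=C=S)cc3)nc2n1C1CCCC1`, gives 32.9% in this assay.

Within the data shown here, compound 2 holds the higher of the two numbers measured so far in this assay, though its nearest neighbour, compound 1, sits only a little lower, and the gap between them is within the scatter of repeated measurements. Compound 1 and compound 2 differ in more than one place, so their two values show only that both land at a similar level.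

The next compound, compound 3, `CN(C)C(=O)c1cc2cnc(Nc3ccc(C(=O)NCCCCCCCN=C=S)cc3)nc2n1C1CCCC1`, has not yet been measured. Relative to compound 2 the change is a group of 7 heavy atoms (5 carbon, 1 nitrogen, 1 sulfur; no ring) in place of a group of 3 heavy atoms (1 carbon, 1 nitrogen, 1 sulfur; no ring), on a saturated chain carbon, three bonds along the chain from an amide-type nitrogen. Compound 1 already carries the longer tether and reaches about the same inhibition as compound 2, so no step beyond the scatter is expected here; the estimated step of a number 0.1 percentage points higher from compound 2 to compound 3 (within the scatter) is essentially flat. Compound 3 is therefore expected to give about 33%, with a likely range from 20% to 46%.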

Compound 3, a percentage reported as inhibition, at one concentration (the size of the read-out at that concentration, not a potency): 73.7%
Beside the measured number, compound 3's estimate is 40.7 percentage points below it; measured number outside the range, above it.
By their numbers in this assay, from the lowest: compounds 1 and 2 (each within the scatter of the next); then compound 3.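

On the amide-linked scaffold, this position proves sensitive to the length of the chain carrying the isothiocyanate: in this assay, the group of 7 heavy atoms in place of the group of 3 heavy atoms gives a number 40.8 percentage points higher from compound 2 to compound 3 (beyond the scatter). The earlier pair could not show this, as compound 1 and compound 2 differ in more than one place. The longer tether does not bring a high number in every setting, since compound 1, which also carries it, gives 32.6%, whereas compound 3 gives 73.7%. No measurement available here explains the gain.

The compounds shown leave open whether the inhibition changes gradually or abruptly at chain lengths between these two, and whether a still longer chain raises it further. They also leave open whether the tether would hold this level with an amine in place of the isothiocyanate.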